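A bromo-hydroxyphenyl analogue of compound 2

The source may hold more compounds than are shown below. What is called first, only, known or untested is meant among the compounds shown, and "the series" means these compounds.

In a functional assay on PC-3 cells (Homo sapiens) for inhibition (on this read-out higher numbers stand for weaker inhibition and lower numbers for stronger inhibition), compound 2 `Cc1c(C(=O)N/N=C\c2ccccc2)oc2cccc(O)c12` gives 29200 nM, the highest of the two numbers shown. Compound 1 `Cc1c(C(=O)N/N=C\c2cccc(O)c2)oc2cccc(O)c12` gives 17600 nM, and the step of a 1.7-fold higher number from compound 1 to compound 2 (0.22 log units; within the scatter) stays within the scatter. Compound 3 `Cc1c(C(=O)N/N=C\c2cccc(Br)c2O)oc2cccc(O)c12` carries 3-bromo-2-hydroxyphenyl in place of phenyl on a carbon with a double bond to nitrogen. For the measured compounds named here, the only measured step that bears on this is a 1.7-fold higher number from compound 1 to compound 2 (0.22 log units; within the scatter), in which a hydroxy left the same ring; compound 3 regains a hydroxy and adds a bromo group, for which nothing is known here. A small step in the other direction is therefore expected, a 1.8-fold lower number from compound 2 to compound 3 (0.26 log units; within the scatter), not clearly beyond the scatter. Compound 3 is estimated at 16000 nM, between 5000 nM and 50000 nM.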

Compound 3, half-maximal inhibitory concentration: 16600 nM
The estimate for compound 3 lay 1.0-fold (0.02 log units) below the measured number; low and high end bracket the measured number.
By their numbers in this assay, from the lowest: compounds 3, 1 and 2 (each within the scatter of the next).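

In this assay, 3-bromo-2-hydroxyphenyl in place of phenyl on a carbon with a double bond to nitrogen gives a 1.8-fold lower number from compound 2 to compound 3 (0.25 log units; within the scatter), and the same group in place of 3-hydroxyphenyl gives a 1.1-fold lower number from compound 1 to compound 3 (0.03 log units; within the scatter). This position therefore takes a bromo and a hydroxy group together with no step beyond the scatter, so all three compounds remain within the scatter of one another. Nothing available explains these small steps.

Going by these compounds, the share of the bromo group alone stays open, as does whether an amine or a carboxylic acid on this ring would give a step beyond the scatter.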